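The source may report more compounds than this note shows. Statements on the series, on what has been measured and on what is new or still open speak of the compounds shown alone.

Compound 1 (`CC[C@@H]1C[C@H](CC)CN(CCCNC(=O)C2CCN(Cc3nc(-c4ccccc4C)oc3C)CC2)C1`) gives 0.0917 h in an ADME assay on microsomes from liver (Rattus norvegicus) for metabolic stability, read by LC-MS, using NADPH, at 37 degrees C (a higher number here means that the compound lasts longer, a lower number that the compound disappears faster), and compound 2 (`Cc1ccccc1-c1nc(CN2CCC(C(=O)NCCCN3CCC(C(C)C)CC3)CC2)c(C)o1`) gives 0.147 h, with a 1.6-fold higher number from compound 1 to compound 2 (0.20 log units; within the scatter). Compound 3 (`Cc1ccccc1-c1nc(CN2CCC(C(=O)NCCCN3CCC(C)CC3)CC2)c(C)o1`) reads > 0.5 h, which is a limit of the assay and not a number. Compound 4 (`Cc1ccccc1-c1nc(CN2CCC(C(=O)NCCCN3[C@H](C)CCC[C@@H]3C)CC2)c(C)o1`) differs from it as follows: 2,6-dimethylpiperidin-1-yl in place of 4-methylpiperidin-1-yl on a saturated chain carbon, three bonds along the chain from an amide-type nitrogen, that is, 2,6-dimethylpiperidin-1-yl in place of 4-methylpiperidin-1-yl. Among the compounds with values here, two measured steps bear on this change: an at least 5.4-fold higher number from compound 1 to compound 3 (0.73 log units; beyond the scatter) and an at least 3.4-fold higher number from compound 2 to compound 3 (0.53 log units; beyond the scatter). Within the data shown here, each ends on 4-methylpiperidin-1-yl, and no measured compound carries 2,6-dimethylpiperidin-1-yl, so the reading across is loose. A modest fall in this assay is expected: an at least 2.0-fold lower number from compound 3 to compound 4 (0.30 log units; that floor lies within the scatter). For compound 4 the estimated half-life is 0.25 h, with an expected range of 0.1 h to 0.6 h.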

Compound 4, half-life: > 0.5 h
Compound 4: only a limit was reported (the forecaster's own chance of this, stated with the estimate: 25%); at least 2.0-fold (0.30 log units) between middle value and limit.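

Compound 4 reads > 0.5 h, which is a limit of the assay and not a number. The change to 2,6-dimethylpiperidin-1-yl gives an at least 3.4-fold higher number from compound 2 to compound 4 (0.53 log units; beyond the scatter) and an at least 5.4-fold higher number from compound 1 to compound 4 (0.73 log units; beyond the scatter). Within the data shown here, on this saturated chain carbon, 4-methylpiperidin-1-yl is therefore no longer the only group to reach the limit.

On these data alone, the step between compound 3 and compound 4 cannot be read, as both values are limits: the limit of > 0.5 h in this assay, at which 2 of the 4 values shown sit. How far either compound lies past that limit stays open, as does the outcome with morpholin-4-yl at this place.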